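Stability Estimate for a Piperazine-to-Aminoalcohol Exchange

A few compounds are considered here, and "the series" means these few. Any claim that something is new, unique, unknown or untested is made for them only; others in the source may bear on it.

Of the compounds shown here, two share a sulfonamide-ether-amide core and have been tested in an ADME assay on microsomes from liver (Homo sapiens) for metabolic stability, with a stated time of 30 min, tested at 1 uM; on this read-out lower numbers stand for a less stable compound and higher numbers for a more stable compound. Compound 1 `COc1cc(C)c(S(=O)(=O)N(C)CCOCC(=O)N2CCC(N3CCN(C(C)C)CC3)CC2)c(C)c1` gives 54% in this assay, and compound 2 `COc1cc(C)c(S(=O)(=O)N(C)CCOCC(=O)N(C)Cc2ccc(C3=NCCN3)cc2)c(C)c1` gives 57%. Compound 1 carries the lower of the two numbers, but the gap to compound 2 lies within the scatter, so the two cannot be told apart on this read-out. Compound 3 `COc1cc(C)c(S(=O)(=O)N(C)CCOCC(=O)N2CCC(C(O)CN(C)C)CC2)c(C)c1` has not yet been tested. It differs from compound 1 in one place: 2-(dimethylamino)-1-hydroxyethyl in place of 4-isopropylpiperazin-1-yl on a saturated ring carbon. Going by the values given here, no step between two measured compounds that differ in a single place is available to anchor the change, and the two measured values give no trend. Compound 3 is therefore expected to stay close to compound 1, with a step of a number 4 percentage points higher from compound 1 to compound 3 (within the scatter) that is not expected to exceed the scatter. For compound 3 an estimate of 58% is given, within a range from 40% to 76%.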

Compound 3, percent of the compound remaining: 100%
Estimate against measurement, compound 3: 42 percentage points below; measured number outside the range, above it.
By their numbers in this assay, from the lowest: compounds 1 and 2 (each within the scatter of the next); then compound 3.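

Going by these compounds alone, exchanging 4-isopropylpiperazin-1-yl for 2-(dimethylamino)-1-hydroxyethyl on this saturated ring carbon gives a number 46 percentage points higher from compound 1 to compound 3 (beyond the scatter) in this assay, the first step between compounds that differ in one place, and it shows that this read-out responds strongly to the group at this position. Within the data shown here, the change removes a six-membered ring, lowers the heavy-atom count and brings in a hydrogen-bond donor, and all of these differences arrive together in the one step. Nothing available explains why the step is so large.

The compounds shown leave open whether the step goes with the hydroxy group or with the open chain in place of the ring. Going by these compounds, a plain 2-(dimethylamino)ethyl group at the same ring carbon would separate the two, and it remains open whether the step would hold on a different amide.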